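Hydroxybenzyl for hydroxycyclohexyl on the ether oxygen

The compounds below may be only part of what the source reports. "The series", "measured", "known", "first", "only" and "open" are said of these compounds alone.

The measured compounds and their values in a functional assay on HL-60 cells (Homo sapiens) for inhibition, read by CCK-8 assay, with a stated time of 48 h (on this read-out higher numbers stand for weaker inhibition and lower numbers for stronger inhibition), are:
compound 1, `O=C(NCCNS(=O)(=O)c1ccc(-c2ccccc2OCc2ccccc2)s1)Nc1cc(Cl)cc(Cl)c1`, 11700 nM;
compound 2, `CC(C)c1ccc(Oc2ccc(O)c(O)c2)c(-c2ccsc2S(=O)(=O)NCCNC(=O)Nc2cc(Cl)cc(Cl)c2)c1`, 6500 nM;
compound 3, `O=S(=O)(NCCNC(=S)Nc1cc(C(F)(F)F)cc(C(F)(F)F)c1)c1ccc(-c2ccccc2O[C@H]2CC[C@@H](O)CC2)s1`, 2600 nM.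

Compound 3 has the lowest number of the three. The nearest is compound 2, whose value is beyond the scatter from it, and the furthest is compound 1, whose value lies further still. For the measured compounds named here, the three compounds differ in several places at once, so no single-change step can be drawn between any pair of them; their values show only where each stands.

Compound 4 is `O=S(=O)(NCCNC(=S)Nc1cc(C(F)(F)F)cc(C(F)(F)F)c1)c1ccc(-c2ccccc2OCc2cccc(O)c2)s1`. It differs from compound 3 in one place: 3-hydroxybenzyl in place of 4-hydroxycyclohexyl on an oxygen on an aromatic ring. The group that leaves is 4-hydroxycyclohexyl, the group that enters is 3-hydroxybenzyl, and the place is an oxygen on an aromatic ring whose other neighbour is an aromatic carbon.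

Going by the values given here, no measured pair shows this change. Compound 1 carries a benzyl on the corresponding oxygen but also a different urea and a different aryl amine, so its value cannot be read as a step. For compound 4 in this assay an estimate of 3200 nM is given, within 1300 nM to 8000 nM. The expected step is a 1.2-fold higher number from compound 3 to compound 4 (0.09 log units; within the scatter), which is not expected to go beyond the scatter in either direction.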

Compound 4, half-maximal inhibitory concentration: > 50000 nM
Compound 4: only a limit was reported (the forecaster's own chance of this, stated with the estimate: 5%); at least 15-fold (1.19 log units) between middle value and limit.
By their numbers in this assay, from the lowest: compound 3; then compounds 2 and 1 (each within the scatter of the next). At a limit, above all of these: compound 4.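

In this assay, for the compounds shown here, the change on this oxygen gives an at least 19-fold higher number from compound 3 to compound 4 (1.28 log units; beyond the scatter), so the position is far from indifferent to the group it carries, which the earlier compounds could not show. The result for compound 4 is a limit of the assay and not a number: the limit of > 50000 nM in this assay, at which 1 of the 4 values shown sits. The 4-hydroxycyclohexyl and 3-hydroxybenzyl groups each count 1 hydrogen-bond donor and 1 hydrogen-bond acceptor, so these counts alone do not keep the inhibition seen with compound 3.

The compounds shown leave open whether the loss follows from the aromatic ring itself or from where the hydroxyl sits on it. They also leave open whether an amine in place of the hydroxyl on the cyclohexyl ring would hold the value of compound 3.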